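The compounds below may be only part of what the source reports. "The series", "measured", "known", "first", "only" and "open" are said of these compounds alone.

Measured so far:
Compound 1 `O=C(CN1C(=O)C2(OCCCCO2)c2cc(Cl)ccc21)NO`: 91500 nM
Compound 2 `O=C(CN1C(=O)C2(OCCCCO2)c2cc(F)ccc21)NO`: 114000 nM

Both values come from a functional assay on MDA-MB-231 cells (Homo sapiens) for cytotoxicity, read by MTT assay, with a stated time of 48 h; on this read-out lower numbers stand for stronger inhibition and higher numbers for weaker inhibition. Among the compounds with values here, with only two compounds on the scale, compound 2, at 114000 nM, stands within the scatter of compound 1, its one neighbour, and the numbers do not separate them.

The next compound, compound 3 `O=C(CN1C(=O)C2(OCCCCO2)c2cc(Br)ccc21)NO`, keeps the shared core and changes only the halogen: bromo in place of fluoro on an aromatic carbon. In words, this is bromo in place of fluoro on an aromatic carbon.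

Within the data shown here, one measured step bears on this change: a 1.2-fold higher number from compound 1 to compound 2 (0.10 log units; within the scatter), which was fluoro in place of chloro on an aromatic carbon. Among the measured compounds shown here, no measured compound yet carries bromo, so this evidence is thin and indicates no direction. Resting on that single small step, no change beyond the scatter is expected in this assay.

For compound 3 the expected value is 90000 nM, with an estimated range of 42000 nM to 180000 nM. This estimate means an expected 1.3-fold lower number from compound 2 to compound 3 (0.10 log units; within the scatter).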

Compound 3, half-maximal inhibitory concentration: 32900 nM
The estimate for compound 3 lay 2.7-fold (0.44 log units) above the measured number, outside the stated range (below it).
By their numbers in this assay, from the lowest: compound 3; then compounds 1 and 2 (each within the scatter of the next).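

In this assay the halogen on this aromatic carbon of the six-membered aromatic ring proves able to move the number: bromo in place of fluoro gives a 3.5-fold lower number from compound 2 to compound 3 (0.54 log units; beyond the scatter) and bromo in place of chloro gives a 2.8-fold lower number from compound 1 to compound 3 (0.44 log units; beyond the scatter), both modest steps beyond the scatter. The exchange of chloro and fluoro had not separated compound 1 from compound 2, whereas bromo separates compound 3 from both, so among these three compounds only bromo comes with a change that the scatter does not cover. Nothing on hand accounts for why bromo stands apart from the other two halogens, and the numbers record the difference without explaining it.

The compounds shown leave open whether the lower number belongs to bromo alone or would also appear with iodo, or with a non-halogen such as methyl or methoxy on the same aromatic carbon. They also leave open whether the bromo step would persist in this assay on a version of the shared core that carries a carboxylic acid at the end of its side chain.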